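Aryl ketone series: 4-aminophenyl exchanged for 3,4-dichlorophenyl

This account rests on a few compounds, and the source may have more. Where it says the series, first, only, none or still open, it means among the compounds named here.

Measured so far:
compound 1 `COc1cc(-c2cc(/C=C/C(=O)c3ccc(N)cc3)[nH]n2)cc(OC)c1OC` — in a functional assay on OVCAR-4 cells (Homo sapiens) for cytotoxicity, read by sulforhodamine B assay, with a stated time of 48 h, tested at 10 uM (a lower number here means a stronger effect, a higher number a weaker effect of the compound at the concentration tested), compound 1 gives -22%
compound 2 `COc1ccc(-c2cc(/C=C/C(=O)c3ccc(OC)c(OC)c3)[nH]n2)cc1` — in this assay compound 2 gives -27%

Only these two readings exist in this assay. The number for compound 1 and the number for compound 2 lie within the usual scatter of one another, so the two cannot be told apart on this evidence, and neither can be called the stronger. Within the data shown here, no two measured compounds differ in a single place, so no step within the measured set is known.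

Compound 3 `COc1cc(-c2cc(/C=C/C(=O)c3ccc(Cl)c(Cl)c3)[nH]n2)cc(OC)c1OC` has not been measured. Against compound 1 the change is 3,4-dichlorophenyl in place of 4-aminophenyl on a carbonyl carbon. Among the measured compounds shown here, nothing among the measured compounds resembles this exchange, and the two known readings give no spread to lean on. The step of a number 6 percentage points lower from compound 1 to compound 3 (within the scatter) is therefore expected to stay within the scatter, with no direction favoured. Given that compound 1 gives -22% in this assay, compound 3 is expected to read near that figure. For the measured compounds named here, the estimate for compound 3 is -28%, with a range from -55% to 0%, the width reflecting that the change rests on no measured precedent.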

Compound 3, a percentage reported as activity, at one concentration (the size of the read-out at that concentration, not a potency): 52%
Compound 3: middle estimate off by 80 percentage points, on the low side; the whole stated range lies below it.
By their numbers in this assay, from the lowest: compounds 2 and 1 (each within the scatter of the next); then compound 3.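

In this assay the aryl group on the carbonyl carbon proves to be far from a silent place: 3,4-dichlorophenyl in place of 4-aminophenyl gives a number 74 percentage points higher from compound 1 to compound 3 (beyond the scatter) and leaves compound 3 at 52% as a clearly weaker agent at the concentration tested. Among these compounds, this is the first single-place step, and it shows a sensitivity to this exchange that the two earlier readings, lying within the scatter of one another and differing in more than one place, could not reveal. No measurement at hand accounts for the size of this step, which so far rests on one pair of compounds.

The compounds shown leave open whether the step follows the loss of the amine, the arrival of the two chlorines, or both together; a plain phenyl on the same carbonyl carbon would begin to separate these. Also open, from the compounds shown here alone, is whether the 3,4-dichlorophenyl and 4-aminophenyl exchange would give a step of similar size on a core other than that of compound 1.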